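Chain Changes and Half-Life: From Compound 3 to Compound 4

The source may report more compounds than this note shows. Statements on the series, on what has been measured and on what is new or still open speak of the compounds shown alone.

In an ADME assay for pharmacokinetics (on this read-out higher numbers stand for a longer-lived compound and lower numbers for a shorter-lived compound), compound 1 `Cc1cn(C2CC(N=[N+]=[N-])C(COC(=O)OCCCO)O2)c(=O)[nH]c1=O` gives 0.167 h, compound 2 `Cc1cn(C2CC(N=[N+]=[N-])C(COC(=O)OCCCCO)O2)c(=O)[nH]c1=O` gives 0.5 h and compound 3 `Cc1cn(C2CC(N=[N+]=[N-])C(COC(=O)OCCCCCO)O2)c(=O)[nH]c1=O` gives 0.267 h. Compound 3 cannot be told apart from either of the others, as a 1.6-fold higher number from compound 1 to compound 3 (0.20 log units; within the scatter) and a 1.9-fold lower number from compound 2 to compound 3 (0.27 log units; within the scatter) both show. Only a 3.0-fold higher number from compound 1 to compound 2 (0.48 log units; beyond the scatter) goes beyond the scatter.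

Compound 4 `CCCCOC(=O)OCC1OC(n2cc(C)c(=O)[nH]c2=O)CC1N=[N+]=[N-]` differs from compound 3 as follows: hydrogen in place of hydroxymethyl on a saturated chain carbon, four bonds along the chain from an oxygen next to a carbonyl group. This is hydrogen in place of hydroxymethyl on a saturated chain carbon, four bonds along the chain from an oxygen next to a carbonyl group, which also reads as 4-hydroxybutyl to propyl.

Among the measured compounds shown here, no measured step removes the hydroxy group outright, so the evidence is indirect. For the measured compounds named here, the closest precedent acts at the same place, and a 1.9-fold lower number from compound 2 to compound 3 (0.27 log units; within the scatter) stays within the scatter. The three measured compounds also span a narrow range. A shift beyond the scatter in this assay is therefore not expected, though this expectation is tentative.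

The expected step is a 1.1-fold higher number from compound 3 to compound 4 (0.05 log units; within the scatter). The estimate for compound 4 is 0.3 h, with an expected range of 0.12 h to 0.75 h.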

Compound 4, half-life: 0.15 h
The estimate for compound 4 lay 2.0-fold (0.30 log units) above the measured number; the measured number falls inside the stated range.
By their numbers in this assay, from the lowest: compounds 4, 1, 3 and 2 (each within the scatter of the next, the first and the last beyond it).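

Replacing the hydroxymethyl of compound 3 with hydrogen, which turns 4-hydroxybutyl into propyl, gives the first direct read on a chain without a hydroxy group in this assay and leaves no clear mark, with a 1.8-fold lower number from compound 3 to compound 4 (0.25 log units; within the scatter) and with a 1.1-fold lower number from compound 1 to compound 4 (0.05 log units; within the scatter) as well. The comparison with compound 2 reads differently, as a 3.3-fold lower number from compound 2 to compound 4 (0.52 log units; beyond the scatter) is only the second step in the set to pass the scatter. Compound 2 now stands clear of both compound 1 and compound 4, while compound 3 remains within the scatter of all three, so it goes against any simple sorting by chain. Nothing shown explains these differences.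

From the compounds shown here alone, whether an amine or a carboxylic acid at the chain end would behave like the hydroxy group remains open. So does the effect of a longer chain than that of compound 3 on this read-out.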